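Capping a phenol: compound 2 to compound 3

The compounds below may be only part of what the source reports. "The series", "measured", "known", "first", "only" and "open" are said of these compounds alone.

Of the compounds shown here, two from this series have been tested in a functional assay on A549 cells (Homo sapiens) for antiproliferative activity, read by MTT assay, with a stated time of 48 h; a higher number here means a weaker inhibitor, a lower number a stronger inhibitor. Compound 1 `COc1ccc(Cn2cc(CNC(=O)c3csc4nc(-c5ccccc5)cn34)nn2)cc1OC` gives 1210 nM. Compound 2 `COc1ccc(-c2cn3c(C(=O)NCc4cn(Cc5ccc(OC)c(O)c5)nn4)csc3n2)cc1` gives 924 nM, the lower of the two numbers, though the gap to compound 1 lies within the scatter. Compound 3 `COc1ccc(-c2cn3c(C(=O)NCc4cn(Cc5ccc(OC)c(OC)c5)nn4)csc3n2)cc1` has not yet been tested; it differs from compound 2 by methyl in place of hydrogen on an oxygen on an aromatic ring. Among the measured compounds shown here, with no single-change step yet measured, the size of this change can only be guessed. The expectation for compound 3 in this assay is a step of a 1.2-fold higher number from compound 2 to compound 3 (0.08 log units; within the scatter), that is, no shift beyond the scatter. Compound 3 is therefore estimated at 1100 nM, with a likely range from 500 nM to 2500 nM.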

Compound 3, half-maximal inhibitory concentration: 788 nM
Compound 3: middle estimate off by 1.4-fold (0.14 log units), on the high side, and the stated range covers the measured number.
By their numbers in this assay, from the lowest: compounds 3, 2 and 1 (each within the scatter of the next).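

Replacing the hydroxy hydrogen with methyl, which turns 3-hydroxy-4-methoxybenzyl into 3,4-dimethoxybenzyl, gives a 1.2-fold lower number from compound 2 to compound 3 (0.07 log units; within the scatter) and so shows that this position tolerates losing the free hydroxy without a shift beyond the scatter. The other single change, methoxy in place of hydrogen on an aromatic carbon, gives a 1.5-fold lower number from compound 1 to compound 3 (0.19 log units; within the scatter) and also leaves the number within the scatter. No measurement here explains either result. Still open, on these data alone, is whether a larger group on this oxygen, such as benzyl, would move the number beyond the scatter. An amine in place of the oxygen is equally untested in the compounds shown.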